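This account rests on a few compounds, and the source may have more. Where it says the series, first, only, none or still open, it means among the compounds named here.

Measured compounds:
Compound 1 `O=C(Nc1cccc(-n2cc(-c3ccncc3)c(-c3cc(O)cc(Cl)c3)n2)c1)Nc1ccc(Cl)c(Cl)c1` – in a functional assay on Malme-3M cells (Homo sapiens) for inhibition, read by sulforhodamine B assay, with a stated time of 48 h, tested at 0.01 uM (on this read-out higher numbers stand for a weaker effect at the one concentration tested and lower numbers for a stronger effect), compound 1 gives 57%.
Compound 2 `COc1cc(Cl)cc(-c2nn(-c3cccc(NC(=O)Nc4ccc(Cl)c(Cl)c4)c3)cc2-c2ccncc2)c1` – in this assay compound 2 gives 92%.

For the measured compounds named here, compound 2 stands highest of the two measured numbers; its nearest neighbour is compound 1, and the one measured step, a number 35 percentage points higher from compound 1 to compound 2 (beyond the scatter), lies beyond the scatter.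

Compound 3 `COc1cc(Cl)cc(-c2nn(-c3cccc(NC(=O)c4cccc(C(F)(F)F)c4)c3)cc2-c2ccncc2)c1` has not been measured. It differs from compound 2 in one place: 3-(trifluoromethyl)phenyl in place of (3,4-dichlorophenyl)amino on a carbonyl carbon. Going by the values given here, no measured step bears on this change; the only step known concerns methyl in place of hydrogen on an oxygen on an aromatic ring, a different position, so the data give no guide to how the carbonyl carbon substituent matters. With the high number of compound 2 as the only anchor, the estimate for compound 3 is 90% (range 70% to 108%), the expected step of a number 2 percentage points lower from compound 2 to compound 3 (within the scatter) lying within the scatter.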

Compound 3, a percentage reported as activity, at one concentration (the size of the read-out at that concentration, not a potency): 58%
Compound 3: middle estimate off by 32 percentage points, on the high side; measured number below the stated range.
By their numbers in this assay, from the lowest: compounds 1 and 3 (each within the scatter of the next); then compound 2.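

In this assay the group on the carbonyl carbon proves to be a second place where the read-out moves, alongside the oxygen on the aromatic ring: 3-(trifluoromethyl)phenyl in place of (3,4-dichlorophenyl)amino gives a number 34 percentage points lower from compound 2 to compound 3 (beyond the scatter), a stronger effect at the one concentration tested. This single change removes the hydrogen-bond donor of the leaving group and exchanges chlorine for fluorine, so the step cannot say which part of the swap carries the shift. Nothing available here explains the shift.

On these data alone, it remains open whether a simple amine such as dimethylamino or a short alkyl chain on the carbonyl carbon would keep this stronger effect. It is also unknown whether hydrogen in place of methyl on the oxygen would move compound 3 as it moves compound 2.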